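The compounds below may be only part of what the source reports. "The series", "measured", "known", "first", "only" and "open" are said of these compounds alone.

Within the data shown here, compound 2 `COC(=O)C1=C(C)N=C(C)/C(=C(\O)OC)C1c1ccccc1I` is one of two compounds measured in a functional assay (muscle tissue) with Cavia porcellus as the target; a lower number here means that less compound is needed, a higher number that more compound is needed for the effect. In this assay compound 2 gives 46.8 nM. The other compound, compound 1 `COC(=O)C1=C(C)NC(C)=C(C(=O)OC)C1c1ccccc1`, gives 28.2 nM in this assay, and the two numbers lie within the usual scatter of each other, so compound 2 cannot be set apart from compound 1 on these values; it simply holds the higher of the two numbers shown.

Compound 3 `COC(=O)C1=C(C)N=C(C)/C(=C(\O)OC)C1c1ccc(C#N)cc1` has not yet been measured. It differs from compound 2 in one place: 4-cyanophenyl in place of 2-iodophenyl on a saturated ring carbon. Among the measured compounds shown here, no step between two measured compounds matches this change, so there is no measured step on which to lean. For the measured compounds named here, the only guide is that compound 1 and compound 2 carry different groups at this same ring carbon and yet sit close together: compound 1 gives 28.2 nM and compound 2 gives 46.8 nM. On that basis compound 3 is expected to need somewhat more compound than compound 2, a step of a 3.2-fold higher number from compound 2 to compound 3 (0.51 log units; beyond the scatter), beyond the scatter but modest. The estimate for compound 3 in this assay is 150 nM, with a range from 40 nM to 600 nM.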

Compound 3, half-maximal effective concentration: 3470 nM
Compound 3: middle estimate off by 23-fold (1.36 log units), on the low side; the measured number lies above the stated range.
By their numbers in this assay, from the lowest: compounds 1 and 2 (each within the scatter of the next); then compound 3.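

In this assay, 4-cyanophenyl in place of 2-iodophenyl on the saturated ring carbon gives a 74-fold higher number from compound 2 to compound 3 (1.87 log units; beyond the scatter) and is a large step, so what this carbon carries can move the number far beyond the scatter. Compound 1 and compound 2 had not shown this, since their values lie within the scatter of each other and gave no measured step at this position. The step also shows that an exchange of one substituted phenyl group for another can matter greatly here, although no measurement shown explains why this one does.

The change alters both the substituent, iodine giving way to nitrile, and its place on the phenyl ring, so the compounds shown cannot say which of the two accounts for the higher number; 2-cyanophenyl and 4-iodophenyl would separate them. They also leave open how this carbon would respond to a phenyl ring bearing a different kind of group, such as an amine or a carboxylic acid, and whether the large step would hold with other groups at the 4-position of the phenyl ring.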